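Alkyne-linked bicyclic amides as positive modulators of glutamate receptor 5

A few compounds are considered here, and "the series" means these few. Any claim that something is new, unique, unknown or untested is made for them only; others in the source may bear on it.

Measured so far in an assay on HEK293 cells for positive allosteric modulation of metabotropic glutamate receptor 5 (Homo sapiens), read by FLIPR, with a stated time of 1 h; a higher number here means that more compound is needed for the effect, a lower number that less compound is needed:
compound 1 `O=C1NCCc2nc(C#Cc3cccc(F)c3)sc21`: 290 nM
compound 2 `CC1CC1C(=O)N1CCc2nc(C#Cc3ccccc3)sc2C1`: 9.4 nM
compound 3 `CC(C)S(=O)(=O)N1Cc2nc(C#Cc3ccccc3)sc2C1`: > 10000 nM

Compound 2 gives the lowest of the two numbers shown. The nearest number is that of compound 1, and the gap between them lies beyond the scatter. Compound 3 gives only a limit of this assay and no number, which is the limit of > 10000 nM in this assay, at which 1 of the 3 values shown sits; its value cannot be placed on the same scale.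

The next step keeps the core of compound 2 and changes the group on the carbonyl carbon: compound 4 `O=C(N1CCC(F)CC1)N1CCc2nc(C#Cc3ccccc3)sc2C1` carries 4-fluoropiperidin-1-yl in place of 2-methylcyclopropyl on a carbonyl carbon. Both groups sit on the same carbonyl carbon whose other neighbour is the amide-type nitrogen in the ring, so the change is confined to the substituent itself. For the measured compounds named here, no measured pair in this set isolates such a change, so the size of the step is open. The 2-methylcyclopropyl amide of compound 2 is the best-placed reference, and the expectation is a modest loss, with the step from compound 2 to compound 4 estimated as a 3.2-fold higher number from compound 2 to compound 4 (0.50 log units; beyond the scatter). Compound 4 is therefore expected at about 30 nM in this assay, with a range from 5 nM to 250 nM.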

Compound 4, half-maximal effective concentration: 74 nM
Compound 4: the middle estimate sits 2.5-fold (0.39 log units) below what was measured; the measured number falls inside the stated range.
By their numbers in this assay, from the lowest: compound 2; then compound 4; then compound 1. At a limit, above all of these: compound 3.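

Working from the one comparison that changes a single place, in this assay the carbonyl carbon accepts a switch from 2-methylcyclopropyl to the larger 4-fluoropiperidin-1-yl at a cost in potency (a 7.9-fold higher number from compound 2 to compound 4 (0.90 log units; beyond the scatter)). For the compounds shown here, this is the first measured step at this position, and compound 4 still gives a number rather than a limit, so a six-membered ring with a hetero atom remains workable here, though compound 2 stays the better of the pair. Going by these compounds alone, nothing measured so far explains the size of this step.

Open, from the compounds shown here alone, is whether the higher number follows the fluorine, the ring nitrogen or the ring size, which an unsubstituted piperidin-1-yl or a plain cyclopropyl on the same carbonyl carbon would help to separate. Also open, going by these compounds, is how a morpholin-4-yl or a longer alkyl chain would read at this place.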